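This account rests on a few compounds, and the source may have more. Where it says the series, first, only, none or still open, it means among the compounds named here.

Of the compounds shown here, two have so far been tested in a functional assay on the whole organism with Mus musculus as the target; a higher number here means that more compound is needed for the effect, a lower number that less compound is needed. Compound 1, `CCCC[C@](C)(OC)[C@H](O)/C=C/C1[C@H](O)C[C@H](O)[C@@H]1C/C=C\CCCC(=O)OC`, gives 1.82 mg/kg in this assay. Compound 2, `CCCC[C@@](C)(OC)[C@@H](O)/C=C/C1[C@H](O)CC(=O)[C@@H]1CCCCCCC(=O)OC`, stands at a limit of the measurement rather than at a number: in this assay compound 2 gives > 4 mg/kg, which is the limit of > 4 mg/kg in this assay, at which 1 of the 2 values shown sits. Compound 3, `CCCC[C@@](C)(OC)[C@H](O)/C=C/C1[C@H](O)CC(=O)[C@@H]1CCCCCCC(=O)OC`, has not been measured yet. Its difference from compound 2 is small on paper: the two compounds have the same atoms and bonds; at least one stereo element is drawn with a configuration in one of them and without one in the other: 1 of 6 stereo elements differ; a stereocentre at a saturated chain carbon is drawn S in compound 2 and R in compound 3. For the measured compounds named here, no step between two measured compounds shows what such a single inversion does, so the direction of the move has to be guessed. A flip of one stereocentre in the chain can matter a great deal or hardly at all, and the starting point is only a limit. Compound 3 is estimated to come in at 3 mg/kg, with a likely range from 0.6 mg/kg to 12 mg/kg. That estimate expects an at least 1.3-fold lower number from compound 2 to compound 3 (0.12 log units; that floor lies within the scatter), with a real chance that only a limit is reported again.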

Compound 3, dose for half-maximal effect: 1.35 mg/kg
Compound 3: middle estimate off by 2.2-fold (0.35 log units), on the high side; measured number inside the range.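

Inverting the single stereocentre at the saturated chain carbon from S to R, with atoms and bonds unchanged, gives in this assay an at least 2.9-fold lower number from compound 2 to compound 3 (0.47 log units; beyond the scatter). For the compounds shown here, this is the first step that isolates this centre, and it shows that this one configuration alone can shift the dose needed for the effect by more than the usual scatter. Compound 2 stands at a limit, so the step gives only a minimum size and the true gap may be larger: the limit of > 4 mg/kg in this assay, at which 1 of the 3 values shown sits.

Going by these compounds, how cleanly the step reflects one configuration against the other stays open, given how this place is drawn in the two compounds: the fact that one of compounds 2 and 3 is drawn with a defined configuration and the other without, at the place where they differ Also open is whether the same inversion has a similar effect in a compound carrying a carboxylic acid in place of the ester.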